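The compounds below may be only part of what the source reports. "The series", "measured", "known", "first", "only" and "open" are said of these compounds alone.

Within the data shown here, compound 3 `NC(=O)N1CCN(C(=S)SCc2cn(Cc3ccc(F)cc3)nn2)CC1` gives 62700 nM in a functional assay on EC9706 cells (Homo sapiens) for cytotoxicity, read by MTT assay, with a stated time of 72 h (on this read-out higher numbers stand for weaker inhibition and lower numbers for stronger inhibition), the highest of the three numbers so far, though both its neighbours lie within the scatter of it: compound 1 `NC(=O)N1CCN(C(=S)SCc2cn(Cc3ccccc3F)nn2)CC1` gives 43100 nM, and compound 2 `O=C(NCc1ccccc1)N1CCN(C(=S)SCc2cn(Cc3ccccc3F)nn2)CC1` gives 38100 nM. Compound 4 `O=C(NC1CCCCC1)N1CCN(C(=S)SCc2cn(Cc3ccc(F)cc3)nn2)CC1` differs from compound 3 by cyclohexyl in place of hydrogen on an amide-type nitrogen. Among the measured compounds shown here, the one measured step that bears on a substituent at this nitrogen is a 1.1-fold lower number from compound 1 to compound 2 (0.05 log units; within the scatter), and the change of fluorine position, a 1.5-fold higher number from compound 1 to compound 3 (0.16 log units; within the scatter), was likewise small. Neither shows a shift beyond the scatter, so no step beyond it is expected here either. Compound 4 is therefore expected near 55000 nM, in a range from 25000 nM to 120000 nM, which would mean a 1.1-fold lower number from compound 3 to compound 4 (0.06 log units; within the scatter).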

Compound 4, half-maximal inhibitory concentration: > 128000 nM
Compound 4: no number, only a limit; the forecaster's own chance of this, stated with the estimate: 10%; at least 2.3-fold (0.36 log units) between middle value and limit.
By their numbers in this assay, from the lowest: compounds 2, 1 and 3 (each within the scatter of the next). At a limit, above all of these: compound 4.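

Compound 4 has no number in this series, only a limit: the limit of > 128000 nM in this assay, at which 1 of the 4 values shown sits. Cyclohexyl in place of hydrogen on the amide-type nitrogen gives an at least 2.0-fold higher number from compound 3 to compound 4 (0.30 log units; that floor lies within the scatter), so this change has a floor that lies within the scatter and no upper end. Unlike a 1.1-fold lower number from compound 1 to compound 2 (0.05 log units; within the scatter), it therefore leaves the size of the effect at this nitrogen unsettled, and it could be small or large.

Still open, from the compounds shown here alone, is how cyclohexyl reads with 2-fluorophenyl, and benzyl with 4-fluorophenyl, on the shared core. Also open, going by these compounds, is whether methyl or a longer chain at this nitrogen would give a number rather than a limit.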